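Two Ureas Measured, a Third Awaits Its Number

The source may report more compounds than this note shows. Statements on the series, on what has been measured and on what is new or still open speak of the compounds shown alone.

compound 1 `COc1ccc(NC(=O)Nn2c(-c3ccccc3)nc3ccccc3c2=O)cc1`: 52%
compound 2 `Cc1cccc(NC(=O)Nn2c(-c3ccccc3)nc3ccccc3c2=O)c1`: 59%

In a functional assay on the whole organism (strain albino) with Mus musculus as the target, at a dose of 100 mg/kg by the intraperitoneal route (a lower number here means less inhibition, a higher number more inhibition at the dose given (going by the name of the read-out)), compound 1 gives 52%, and in this assay compound 2 gives 59%. Within the data shown here, compound 2 stands alongside compound 1 with no separation beyond the scatter, the one measured step being a number 7 percentage points higher from compound 1 to compound 2 (within the scatter). Compound 3 `CCOc1ccc(NC(=O)Nn2c(-c3ccccc3)nc3ccccc3c2=O)cc1` is not yet measured; it differs from compound 2 by 4-ethoxyphenyl in place of 3-methylphenyl on an amide-type nitrogen. This returns an alkoxy group at the same position carried by compound 1, whose number sits close to compound 2. Since a number 7 percentage points higher from compound 1 to compound 2 (within the scatter) was within the scatter, compound 3 is expected to move by a number 5 percentage points lower from compound 2 to compound 3 (within the scatter), with no change beyond the scatter foreseen. Compound 3 is estimated at 54%, between 40% and 68%.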

Compound 3, a percentage reported as inhibition, in the whole organism at one dose (the size of the read-out at that dose, not a potency): 53%
For compound 3 the middle estimate is 1 percentage points above the measured one, and the stated range covers the measured number.
By their numbers in this assay, from the lowest: compounds 1, 3 and 2 (each within the scatter of the next).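

In this assay, the added methyl on the alkoxy chain gives a number 1 percentage points higher from compound 1 to compound 3 (within the scatter), while the exchange of aryl groups gives a number 6 percentage points lower from compound 2 to compound 3 (within the scatter). The amide-type nitrogen has thus carried 3-methylphenyl, 4-methoxyphenyl and 4-ethoxyphenyl with no separation beyond the scatter, so neither the longer alkoxy chain nor the return to an alkoxy group separates compound 3 from the others. No evidence accompanying these numbers bears on the reason for this. As far as these compounds go, whether a butoxy chain, an amine or a carboxylic acid on the phenyl ring would separate from these three remains open.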